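Swapping the aryl group on the piperazine nitrogen

This account rests on a few compounds, and the source may have more. Where it says the series, first, only, none or still open, it means among the compounds named here.

Measured compounds:
compound 1, `CC(C)N1CCN(Cc2csc(N)c2C(=O)c2ccc(Cl)cc2)CC1`, -1%
compound 2, `Nc1scc(CN2CCN(c3ccc(Cl)cc3F)CC2)c1C(=O)c1ccc(Cl)cc1`, -9.2%
compound 3, `Nc1scc(CN2CCN(c3ccc(OC(F)(F)F)cc3)CC2)c1C(=O)c1ccc(Cl)cc1`, 0%

In a functional assay on CHO cells with adenosine receptor A1 (Homo sapiens) as the target, read by cAMP accumulation and immunoassay, with a stated time of 6 min, tested at 0.01 uM (on this read-out higher numbers stand for a weaker effect at the one concentration tested and lower numbers for a stronger effect), compound 2 gives -9.2%. Its two neighbours differ from it only in the group on the ring amine nitrogen, and both steps lie within the scatter: a number 8.2 percentage points lower from compound 1 to compound 2 (within the scatter) and a number 9.2 percentage points higher from compound 2 to compound 3 (within the scatter). The third step, a number 1 percentage points higher from compound 1 to compound 3 (within the scatter), is likewise within the scatter. Put together, the three numbers show no real difference among an isopropyl group, a 4-chloro-2-fluorophenyl group and a 4-(trifluoromethoxy)phenyl group at this position.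

Compound 4, `Nc1scc(CN2CCN(c3ccc(F)c(F)c3)CC2)c1C(=O)c1ccc(Cl)cc1`, is not yet measured. It differs from compound 2 as follows: 3,4-difluorophenyl in place of 4-chloro-2-fluorophenyl on an amine nitrogen in a ring. The steps from compound 1 to compound 2 and from compound 2 to compound 3 bear most directly on it, and both were within the scatter. For compound 4, the expected step of a number 6.2 percentage points higher from compound 2 to compound 4 (within the scatter) is therefore none beyond the scatter. In this assay compound 4 is estimated at -3%, with a range from -13% to 7%.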

Compound 4, a percentage reported as activity, at one concentration (the size of the read-out at that concentration, not a potency): -3.2%
For compound 4 the middle estimate is 0.2 percentage points above the measured one; the measured number falls inside the stated range.
By their numbers in this assay, from the lowest: compounds 2, 4, 1 and 3 (each within the scatter of the next).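

In this assay, a phenyl ring carrying only fluorine on the piperazine nitrogen, with no chlorine, is a further aryl group that cannot be told apart from the 4-chloro-2-fluorophenyl group: the step is a number 6 percentage points higher from compound 2 to compound 4 (within the scatter). The 3,4-difluorophenyl group also cannot be told apart from the 4-(trifluoromethoxy)phenyl group, with a number 3.2 percentage points lower from compound 3 to compound 4 (within the scatter), or from the non-aromatic isopropyl group, with a number 2.2 percentage points lower from compound 1 to compound 4 (within the scatter), so all four groups at this position now give indistinguishable numbers. No measurement is available to explain why these groups give such similar numbers.

The compounds shown leave open whether a different kind of group on this nitrogen, such as a carboxylic acid, an amine or a longer chain, would give a step beyond the scatter. They also leave open whether these four compounds would still match at other concentrations, since a single concentration is not a potency.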